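The source may hold more compounds than are shown below. What is called first, only, known or untested is meant among the compounds shown, and "the series" means these compounds.

Measured in an ADME assay on a cell-free system (plasma, Homo sapiens), read by HPLC, with a stated time of 120 min, at 37 degrees C; a higher number here means that more of the compound is left, a lower number that less of the compound is left:
- compound 1 `C[C@@H]1CN(C(=O)c2nc(Nc3cc(C4CC4)[nH]n3)c3cc(Cl)ccc3n2)CCN1C(=O)OC(C)(C)C`: 73.7%
- compound 2 `C[C@@H]1CN(C(=O)c2nc(Nc3cc(C4CC4)[nH]n3)c3cc(Cl)ccc3n2)CCN1C(=O)OCc1ccccc1`: 86.2%
- compound 3 `CC(OC(=O)C(C)C)OC(=O)N1CCN(C(=O)c2nc(Nc3cc(C4CC4)[nH]n3)c3cc(Cl)ccc3n2)C[C@H]1C`: 17.4%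

Compound 3 stands lowest of the three. Compound 4 `CCOC(=O)N1CCN(C(=O)c2nc(Nc3cc(C4CC4)[nH]n3)c3cc(Cl)ccc3n2)C[C@H]1C` differs from it by hydrogen in place of (isopropylcarbonyl)oxy on a saturated chain carbon bound to an oxygen next to a carbonyl group and a saturated chain carbon. This turns 1-((isopropylcarbonyl)oxy)ethyl into ethyl. When 1-((isopropylcarbonyl)oxy)ethyl entered, the steps were large: a number 56.3 percentage points lower from compound 1 to compound 3 (beyond the scatter) and a number 68.8 percentage points lower from compound 2 to compound 3 (beyond the scatter). Benzyl in place of tert-butyl gave a modest a number 12.5 percentage points higher from compound 1 to compound 2 (beyond the scatter). Losing the (isopropylcarbonyl)oxy should therefore undo most of that drop, so a large rise in this assay is expected. The expected step is a number 64.6 percentage points higher from compound 3 to compound 4 (beyond the scatter). Compound 4 is estimated at 82%, with an expected range of 65% to 97%.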

Compound 4, percent of the compound remaining: 85.3%
Estimate against measurement, compound 4: 3.3 percentage points below; low and high end bracket the measured number.
By their numbers in this assay, from the lowest: compound 3; then compound 1; then compounds 4 and 2 (each within the scatter of the next).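

In this assay, taking away only the (isopropylcarbonyl)oxy gives a number 67.9 percentage points higher from compound 3 to compound 4 (beyond the scatter), so the low number of compound 3 goes with that piece and not with the ethyl left behind. Methyl in place of phenyl gives a number 0.9 percentage points lower from compound 2 to compound 4 (within the scatter), while ethyl in place of tert-butyl gives a number 11.6 percentage points higher from compound 1 to compound 4 (beyond the scatter), so these simpler groups stay far from the drop seen with compound 3. Nothing here explains why that piece matters. Still open, from the compounds shown here alone, is whether an acetyloxy or an amine in the same place would also give a low number.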